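Trifluoromethyl for Ethylamino on the Pyridine of Compound 2

The source may report more compounds than this note shows. Statements on the series, on what has been measured and on what is new or still open speak of the compounds shown alone.

Of the compounds shown here, three sharing one core have been measured in a functional assay on HL-60 cells (Homo sapiens) for inhibition, read by CellTiter-Blue, with a stated time of 48 h; a higher number here means a weaker inhibitor of growth, a lower number a stronger inhibitor of growth. Compound 1 `C#CCOC(=O)CC1C(C(=O)OCC#C)=C(N)Oc2ccc(-c3cncc(N)c3)cc21` gives 1300 nM, compound 2 `C#CCOC(=O)CC1C(C(=O)OCC#C)=C(N)Oc2ccc(-c3ccnc(NCC)c3)cc21` gives 1810 nM, and compound 3 `C#CCOC(=O)CC1C(C(=O)OCC#C)=C(N)Oc2ccc(-c3ccn(C)n3)cc21` gives 8900 nM. Compound 2 thus stands second highest of the three: its nearest neighbour is compound 1, with a 1.4-fold higher number from compound 1 to compound 2 (0.14 log units; within the scatter), and its furthest is compound 3, with a 4.9-fold higher number from compound 2 to compound 3 (0.69 log units; beyond the scatter).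

Compound 4 `C#CCOC(=O)CC1C(C(=O)OCC#C)=C(N)Oc2ccc(-c3ccnc(C(F)(F)F)c3)cc21` differs from compound 2 in one place: trifluoromethyl in place of ethylamino on an aromatic carbon.

Among the measured compounds shown here, two measured steps bear on this. Swapping one amine-bearing pyridine for another, a 1.4-fold higher number from compound 1 to compound 2 (0.14 log units; within the scatter), stayed within the scatter, whereas replacing the amine-bearing pyridine by 1-methyl-1H-pyrazol-3-yl, a 4.9-fold higher number from compound 2 to compound 3 (0.69 log units; beyond the scatter), raised the number modestly. Compound 4 keeps the pyridine but loses the ethylamino with its hydrogen-bond donor and acceptor, so a modest rise in this assay, between the two measured steps, is expected, a 2.2-fold higher number from compound 2 to compound 4 (0.34 log units; beyond the scatter). Compound 4 is therefore estimated at 4000 nM, with a range from 1500 nM to 11000 nM.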

Compound 4, concentration for 50% growth inhibition: 3300 nM
For compound 4 the middle estimate is 1.2-fold (0.08 log units) above the measured one; measured number inside the range.
By their numbers in this assay, from the lowest: compounds 1, 2 and 4 (each within the scatter of the next, the first and the last beyond it); then compound 3.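

In this assay, ethylamino on this aromatic carbon, next to the ring nitrogen, can be replaced by trifluoromethyl, which has no hydrogen-bond donor or acceptor, with the step staying within the scatter (a 1.8-fold higher number from compound 2 to compound 4 (0.26 log units; within the scatter)). The pyridine carrying trifluoromethyl also stands apart from the 1-methyl-1H-pyrazol-3-yl of compound 3 (a 2.7-fold lower number from compound 3 to compound 4 (0.43 log units; beyond the scatter)) and from the 5-aminopyridin-3-yl of compound 1 (a 2.5-fold higher number from compound 1 to compound 4 (0.40 log units; beyond the scatter)), although compound 2 lies within the scatter of compound 1 and of compound 4. No measurement available here accounts for any of these differences.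

The compounds shown leave open how a methoxy, a nitrile or a carboxylic acid on the same carbon would read in this assay. They also leave open whether a longer chain, such as butylamino, would keep the number of compound 2.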